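Shifting the chlorine on the benzyl thioether arm

This account rests on a few compounds, and the source may have more. Where it says the series, first, only, none or still open, it means among the compounds named here.

Compound 1 `CC1=C(C(=O)Nc2ccc([N+](=O)[O-])cc2)C(c2ccc(Br)cc2)N=C(SCc2cccc(Cl)c2)N1` gives 2.6% in a functional assay on the whole organism (artery, strain albino) with Rattus norvegicus as the target, with a stated time of 30 min, at a dose of 10 mg/kg by the oral route; on this read-out higher numbers stand for more inhibition at the one dose given (going by the name of the read-out) and lower numbers for less inhibition. Compound 2 `CC1=C(C(=O)Nc2ccc([N+](=O)[O-])cc2)C(c2cccc([N+](=O)[O-])c2)N=C(SCc2ccccc2)N1` gives 4.1% in this assay, and compound 3 `CC1=C(C(=O)Nc2ccc([N+](=O)[O-])cc2)C(c2cccc([N+](=O)[O-])c2)N=C(SCc2ccccc2Cl)N1` gives 3.6% in this assay. Compound 3 stands second highest of the three numbers, with compound 2 nearest and compound 1 furthest, though all three lie within the scatter of one another. For the measured compounds named here, the one single-change step measured, a number 0.5 percentage points lower from compound 2 to compound 3 (within the scatter), also stays within the scatter. Compound 4 `CC1=C(C(=O)Nc2ccc([N+](=O)[O-])cc2)C(c2cccc([N+](=O)[O-])c2)N=C(SCc2cccc(Cl)c2)N1` differs from compound 3 by 3-chlorophenyl in place of 2-chlorophenyl on a saturated chain carbon bound to a sulfur. Compound 1 already carries the 3-chlorobenzyl group and gives 2.6%, within the scatter of compound 3, so no step beyond the scatter is expected in this assay. Compound 4 is estimated at 3.5%, between 0% and 12%, the expected step being a number 0.1 percentage points lower from compound 3 to compound 4 (within the scatter).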

Compound 4, a percentage reported as inhibition, in the whole organism at one dose (the size of the read-out at that dose, not a potency): 4.1%
Estimate against measurement, compound 4: 0.6 percentage points below; the measured number falls inside the stated range.
By their numbers in this assay, from the lowest: compounds 1, 3, 2 and 4 (each within the scatter of the next).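

In this assay, 3-chlorophenyl in place of 2-chlorophenyl gives a number 0.5 percentage points higher from compound 3 to compound 4 (within the scatter), and chloro in place of hydrogen on the aromatic carbon gives no change at the digits printed from compound 2 to compound 4 (within the scatter), so neither chlorine placement separates from the plain benzyl arm. On the saturated ring carbon, 3-nitrophenyl in place of 4-bromophenyl gives a number 1.5 percentage points higher from compound 1 to compound 4 (within the scatter), so this change does not separate either. No measurement on hand accounts for these numbers.

Open, from the compounds shown here alone, is whether an amine or a carboxylic acid on the benzyl ring, or a longer chain on the sulfur in place of benzyl, would give a step beyond the scatter.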